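Positional isomers of a benzyl ester on a shared core

The compounds below may be only part of what the source reports. "The series", "measured", "known", "first", "only" and "open" are said of these compounds alone.

Measured compounds:
compound 1 `O=c1c2cnn(-c3ccc(F)cc3)c2ncn1CC1(O)CCN(Cc2ccccc2F)CC1`, an assay on Sf21 cells for inhibition of ubiquitin carboxyl-terminal hydrolase 7 (Homo sapiens), read by spectrophotometry, with stated times of 30 min and 2 h; on this read-out higher numbers stand for weaker inhibition and lower numbers for stronger inhibition: 9800 nM
compound 2 `COC(=O)c1cccc(CN2CCC(O)(Cn3cnc4c(cnn4-c4ccc(F)cc4)c3=O)CC2)c1`, in this assay : "not determined" (no result reported)

Going by the values given here, compound 1 is the only member of the series with a number in this assay, and in this assay compound 1 gives 9800 nM. Compound 2 stands without any number, since in this assay compound 2 is recorded as "not determined" (no result reported); nothing can be said about where it sits relative to compound 1.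

Compound 3 `COC(=O)c1ccc(CN2CCC(O)(Cn3cnc4c(cnn4-c4ccc(F)cc4)c3=O)CC2)cc1` differs from compound 2 by 4-(methoxycarbonyl)phenyl in place of 3-(methoxycarbonyl)phenyl on a saturated chain carbon bound to an amine nitrogen in a ring. Among the compounds with values here, with no measured step between two numbered compounds to lean on, the size of the step from compound 2 to compound 3 in this assay cannot be anchored; the expectation is no change beyond the usual scatter, in either direction.

Compound 3 is therefore expected to give roughly 9000 nM in this assay, within a range of 2500 nM to 40000 nM.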

Compound 3, half-maximal inhibitory concentration: 4500 nM
Estimate against measurement, compound 3: 2.0-fold (0.30 log units) above; the range from low to high includes it.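

In this assay, going by these compounds alone, 4-(methoxycarbonyl)phenyl in place of 2-fluorophenyl on a saturated chain carbon bound to an amine nitrogen in a ring gives a 2.2-fold lower number from compound 1 to compound 3 (0.34 log units; beyond the scatter), the first step at this position that can be read. It shows that this position accepts a methoxycarbonyl-bearing ring without loss of inhibition, and that the change here brings a modest gain beyond the usual scatter. No measurement given here bears on what lies behind this step.

With no number for compound 2, the effect of moving the ester from 3-(methoxycarbonyl)phenyl to 4-(methoxycarbonyl)phenyl cannot be read. Also open, on these data alone, is whether the gain belongs to the ester itself, and how a carboxylic acid or a primary amide in place of the methoxycarbonyl group would fare.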